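A few compounds are considered here, and "the series" means these few. Any claim that something is new, unique, unknown or untested is made for them only; others in the source may bear on it.

Of the compounds shown here, two have been measured in a functional assay on MCF7 cells (Homo sapiens) for antiproliferative activity, read by sulforhodamine B assay, with a stated time of 72 h; a higher number here means a weaker inhibitor, a lower number a stronger inhibitor. Compound 1 `Cc1cccc(COc2ccc(-c3cc(CN4CCN(Cc5ccc(C(F)(F)F)cc5)CC4)no3)cc2)c1` gives 4000 nM in this assay. Compound 2 `COc1ccccc1COc1ccc(-c2cc(CN3CCN(Cc4ccc(C(F)(F)F)cc4)CC3)no2)cc1` gives 300 nM in this assay. Within the data shown here, compound 2 therefore holds the lowest number of the two, and the only measured step, a 13-fold lower number from compound 1 to compound 2 (1.12 log units; beyond the scatter), separates it from compound 1. That step changes nothing but the group on a saturated chain carbon bound to an oxygen on an aromatic ring, and it shows that this part of the molecule can move the read-out a long way.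

Compound 3 `COc1cc(COc2ccc(-c3cc(CN4CCN(Cc5ccc(C(F)(F)F)cc5)CC4)no3)cc2)cc(OC)c1` is not yet measured. It differs from compound 2 in the same place: 3,5-dimethoxyphenyl in place of 2-methoxyphenyl on a saturated chain carbon bound to an oxygen on an aromatic ring. Among the measured compounds shown here, the one measured step bears on it only loosely: it involved neither a dimethoxy pattern nor a change starting from compound 2, so the direction cannot be read from it. Because the step of a 13-fold lower number from compound 1 to compound 2 (1.12 log units; beyond the scatter) is large, a shift of comparable size is plausible, and compound 2 already holds the lowest number with 300 nM, so a higher number is the more likely outcome. The expected step is a 5.0-fold higher number from compound 2 to compound 3 (0.70 log units; beyond the scatter). Compound 3 is expected to give 1500 nM in this assay, with a likely range from 300 nM to 8000 nM.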

Compound 3, half-maximal inhibitory concentration: 100 nM
For compound 3 the middle estimate is 15-fold (1.18 log units) above the measured one; the measured number lies below the stated range.
By their numbers in this assay, from the lowest: compound 3; then compound 2; then compound 1.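

This position tolerates more than the earlier pair suggested: the series continues past compound 2, with a 3.0-fold lower number from compound 2 to compound 3 (0.48 log units; beyond the scatter) in this assay, so the 2-methoxyphenyl group does not mark the lowest number reached here. Across the whole set, a 40-fold lower number from compound 1 to compound 3 (1.60 log units; beyond the scatter), which makes 3,5-dimethoxyphenyl the best of the three groups at this place and extends the range already opened by the first step. Both methoxy-bearing compounds have lower numbers than compound 1, but the step from compound 2 to compound 3 alters how many methoxy groups the ring carries and where they sit at the same time, and no measurement bearing on the reason for the gain is available.

The three compounds cannot separate the effect of adding a methoxy group from that of moving one, nor say how a plain phenyl ring would compare. On these data alone, it also remains open whether a different kind of group on this ring, such as an amine or a carboxylic acid, would keep the number low, and whether the trend holds with the trifluoromethyl end of the molecule changed.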